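A sulfamoyl swap on compound 3

A few compounds are considered here, and "the series" means these few. Any claim that something is new, unique, unknown or untested is made for them only; others in the source may bear on it.

In an ADME assay on LLC-MK2 cells (Macaca mulatta) for cytotoxicity, read by spectrophotometry and crystal violet staining, with a stated time of 4 days (a lower number here means that less compound is tolerated, a higher number that more compound is tolerated), compound 1 `CC(C)n1ncc2c(C(=O)Nc3ccncc3)cc(-c3cccs3)nc21` gives 6300 nM and has the lowest number of the three. Compound 2 `CC(C)n1ncc2c(C(=O)Nc3ccc(F)cc3F)cc(-c3cccs3)nc21` reads > 200000 nM and this is a limit of the assay, not a number. Among the compounds with values here, compound 3 `CC(C)n1ncc2c(C(=O)Nc3cc(F)ccc3F)cc(-c3cccs3)nc21` gives 100000 nM and has the highest actual number, with compound 1 as its only numbered neighbour.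

Two measured steps replace pyridin-4-yl on the amide-type nitrogen: an at least 31-fold higher number from compound 1 to compound 2 (1.50 log units; beyond the scatter) and a 16-fold higher number from compound 1 to compound 3 (1.20 log units; beyond the scatter) are both large. The step of an at least 2.0-fold lower number from compound 2 to compound 3 (0.30 log units; that floor lies within the scatter) has a floor within the scatter.

Compound 4 `CC(C)n1ncc2c(C(=O)Nc3cccc(S(N)(=O)=O)c3)cc(-c3cccs3)nc21` has not yet been measured and changes the same place, with 3-sulfamoylphenyl in place of 2,5-difluorophenyl on an amide-type nitrogen on an amide-type nitrogen. Within the data shown here, no measured step makes this swap. Still, a 16-fold higher number from compound 1 to compound 3 (1.20 log units; beyond the scatter) shows that this place can move the number strongly, so a lower number is expected, though a moderate drop rather than a full return to compound 1.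

The expected change is a 2.5-fold lower number from compound 3 to compound 4 (0.40 log units; beyond the scatter) in this assay as a rough estimate. For compound 4 the estimated value is 40000 nM with an expected range from 10000 nM to 150000 nM at this stage.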

Compound 4, half-maximal cytotoxic concentration: 25000 nM
The estimate for compound 4 lay 1.6-fold (0.20 log units) above the measured number; measured number inside the range.
By their numbers in this assay, from the lowest: compound 1; then compound 4; then compound 3. At a limit, above all of these: compound 2.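

In this assay, the 3-sulfamoylphenyl group places compound 4 between the earlier extremes, with a 4.0-fold lower number from compound 3 to compound 4 (0.60 log units; beyond the scatter) and a 4.0-fold higher number from compound 1 to compound 4 (0.60 log units; beyond the scatter), both modest. This position therefore gives intermediate numbers as well as low and high numbers, and a six-membered aromatic ring of carbon only does not by itself hold the number at the level of compound 3. Measured against the limit of compound 2, the change is only a floor, an at least 8.0-fold lower number from compound 2 to compound 4 (0.90 log units; beyond the scatter), and its true size stays unknown: the limit of > 200000 nM in this assay, at which 1 of the 4 values shown sits.

From the compounds shown here alone, whether the number follows the sulfamoyl group or the loss of the two fluorines stays open, as compound 4 differs from compound 3 in both at once. An unsubstituted phenyl, or a phenyl carrying a carboxylic acid or an amine, would help separate these two changes.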